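From 4-chlorophenyl to 4-bromophenyl: working notes

The source may hold more compounds than are shown below. What is called first, only, known or untested is meant among the compounds shown, and "the series" means these compounds.

Measured in a functional assay on HepG2 cells (Homo sapiens) for antiproliferative activity, read by MTT assay, with a stated time of 24 h; on this read-out lower numbers stand for stronger inhibition and higher numbers for weaker inhibition
- compound 1 `O=[N+]([O-])c1ccc(S(=O)(=O)n2c(-c3cn(-c4ccccc4)nc3-c3ccc(F)cc3)nc3ccccc32)cc1` gives 1340 nM
- compound 2 `O=S(=O)(c1ccc(Cl)cc1)n1c(-c2cn(-c3ccccc3)nc2-c2ccc(F)cc2)nc2ccccc21` gives 4230 nM

Compound 2 holds the higher of the two numbers. Compound 3 `O=S(=O)(c1ccc(Br)cc1)n1c(-c2cn(-c3ccccc3)nc2-c2ccc(F)cc2)nc2ccccc21` differs from it by bromo in place of chloro on an aromatic carbon with bromo in place of chloro on an aromatic carbon, para to a large group. Among the compounds with values here, only one measured step bears on this change (the modest 3.2-fold higher number from compound 1 to compound 2 (0.50 log units; beyond the scatter)), and it concerns nitro, not bromo, so it offers a loose guide at best. A small move of uncertain direction is expected, with an estimated step in this assay of a 1.2-fold lower number from compound 2 to compound 3 (0.07 log units; within the scatter) at most modest in size. The estimate for compound 3 is 3600 nM (expected range 1800 nM to 7000 nM).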

Compound 3, half-maximal inhibitory concentration: 2550 nM
For compound 3 the middle estimate is 1.4-fold (0.15 log units) above the measured one; the range from low to high includes it.
By their numbers in this assay, from the lowest: compounds 1, 3 and 2 (each within the scatter of the next, the first and the last beyond it).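

In this assay, bromo in place of chloro at this position gives a 1.7-fold lower number from compound 2 to compound 3 (0.22 log units; within the scatter) and stays within the scatter, as does bromo in place of nitro, with a 1.9-fold higher number from compound 1 to compound 3 (0.28 log units; within the scatter). Compound 3 thus cannot be ordered against either compound 1 or compound 2, although those two lie beyond the scatter of each other. No supporting evidence bears on the reason for these readings.

Open, from the compounds shown here alone, is whether an amine or a carboxylic acid on this aromatic carbon would read apart from these three compounds.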